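Chloro on the quinoline: from compound 3 to compound 4

A few compounds are considered here, and "the series" means these few. Any claim that something is new, unique, unknown or untested is made for them only; others in the source may bear on it.

In a functional assay on the whole organism (blood) with Rattus norvegicus as the target, with stated times of 24 h and 1 h, at a dose of 5 mg/kg by the intraperitoneal route (a lower number here means a weaker effect, a higher number a stronger effect of the compound at the dose given), the three measured compounds gave the following numbers:

Compound 1, `Cc1cccc(C(=O)NCCC2CCN(S(=O)(=O)NC(=O)NC[C@@H]3C[C@@H]4C=C[C@@H]3C4)CC2)n1`, gave 20%.
Compound 2, `COc1ccc(C(=O)NCCC2CCN(S(=O)(=O)NC(=O)NC[C@@H]3C[C@@H]4C=C[C@@H]3C4)CC2)cn1`, gave 11%.
Compound 3, `O=C(NC[C@@H]1C[C@@H]2C=C[C@@H]1C2)NS(=O)(=O)N1CCC(CCNC(=O)c2cccc3cccnc23)CC1`, gave 34%.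

Compound 3 has the highest number of the three. The steps to it are a number 14 percentage points higher from compound 1 to compound 3 (beyond the scatter) and a number 23 percentage points higher from compound 2 to compound 3 (beyond the scatter), both beyond the scatter, so compound 3 stands clearly above the other two, while compounds 1 and 2 cannot be told apart, as a number 9 percentage points lower from compound 1 to compound 2 (within the scatter) lies within the scatter.

Compound 4, `O=C(NC[C@@H]1C[C@@H]2C=C[C@@H]1C2)NS(=O)(=O)N1CCC(CCNC(=O)c2cc(Cl)cc3cccnc23)CC1`, differs from compound 3 in one place: chloro in place of hydrogen on an aromatic carbon. Among the measured compounds shown here, all three measured steps swap one whole aromatic group for another; none of them adds a single chloro to an otherwise unchanged ring, so no measured step bears directly on this change. With no guide from the data, the step of a number 1 percentage points higher from compound 3 to compound 4 (within the scatter) is expected to stay within the scatter, in no particular direction. Compound 4 is therefore estimated at 35%, in the range from 20% to 50%.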

Compound 4, a percentage reported as activity, at one dose (the size of the read-out at that dose, not a potency): 35%
The estimate for compound 4 equals the measured number at the digits printed; low and high end bracket the measured number.
By their numbers in this assay, from the lowest: compounds 2 and 1 (each within the scatter of the next); then compounds 3 and 4 (each within the scatter of the next).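

Chloro on the quinoline is the only change here that adds a single atom to an otherwise unchanged ring, and in this assay the step of a number 1 percentage points higher from compound 3 to compound 4 (within the scatter) shows that this position takes a chloro with no readable change in the number. The clear gap between the quinoline and the two pyridine compounds also remains with the chloro in place, with a number 15 percentage points higher from compound 1 to compound 4 (beyond the scatter) and a number 24 percentage points higher from compound 2 to compound 4 (beyond the scatter) for the change to 6-chloroquinolin-8-yl. The data at hand offer no measurement that could explain this outcome.

As far as these compounds go, it remains open whether a larger or different group at this position, such as bromo, methoxy or an amine, would shift the number. From the compounds shown here alone, it is also open whether a chloro would have the same outcome on the pyridine rings of compound 1 and compound 2.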